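The compounds below may be only part of what the source reports. "The series", "measured", "known", "first", "only" and "open" are said of these compounds alone.

In an in vitro ADME assay on microsomes from liver (Rattus norvegicus) for metabolic stability, read by LC-MS, tested at 1 uM (a lower number here means slower removal, a higher number faster removal of the compound), compound 1 (`COCCN(C)S(=O)(=O)c1ccc(C)c(C#Cc2cc(Cl)ccc2OCC(=O)O)c1`) gives 49 mL.min-1.g-1. Compound 2 (`COCCNS(=O)(=O)c1ccc(C)c(C#Cc2cc(Cl)ccc2OCC(=O)O)c1`) gives < 10 mL.min-1.g-1, which is a limit of the assay and not a number. Compound 2 therefore sits at the limit of < 10 mL.min-1.g-1 in this assay, at which 1 of the 2 values shown sits, and its true position is not known. Compound 3 (`Cc1ccc(S(=O)(=O)N2CCOCC2)cc1C#Cc1cc(Cl)ccc1OCC(=O)O`) carries morpholin-4-yl in place of (2-methoxyethyl)amino on a sulfonyl sulfur. Like compound 1, it has no hydrogen on the sulfonamide nitrogen. Among the measured compounds shown here, the only measured step that bears on this change is an at least 4.9-fold lower number from compound 1 to compound 2 (0.69 log units; beyond the scatter), which is beyond the scatter. Compound 3 differs from compound 1 in having a ring, so that step is only a rough guide, and a somewhat smaller change is anticipated. The estimated change in this assay is upward and beyond the scatter, an at least 2.5-fold higher number from compound 2 to compound 3 (0.39 log units; beyond the scatter). Compound 3 is expected to give 25 mL.min-1.g-1, with an estimated range of 10 mL.min-1.g-1 to 60 mL.min-1.g-1.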

Compound 3, intrinsic clearance in microsomes: 10 mL.min-1.g-1
Compound 3: middle estimate off by 2.5-fold (0.40 log units), on the high side, within the range that was stated.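

The step of a 4.9-fold lower number from compound 1 to compound 3 (0.69 log units; beyond the scatter) in this assay shows a lower number with no hydrogen on the sulfonamide nitrogen, where morpholin-4-yl takes the place of the open (2-methoxyethyl)(methyl)amino group. Among these compounds, then, a hydrogen on that nitrogen is not required for a lower number than that of compound 1. The second step reads a number no lower from compound 2 to compound 3 (the limit leaves the size open) and its size cannot be read. Compound 2 stands at a limit of the assay and not at a number: the limit of < 10 mL.min-1.g-1 in this assay, at which 1 of the 3 values shown sits.

The compounds shown leave open whether the number of compound 3 depends on the ring alone or also on its oxygen, a question that a piperidine ring on the sulfonyl sulfur would address. They also leave open how a piperazine ring at the same place would read in this assay.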